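A few compounds are considered here, and "the series" means these few. Any claim that something is new, unique, unknown or untested is made for them only; others in the source may bear on it.

Measured compounds and their values in an ADME assay on microsomes from liver (Rattus norvegicus) for metabolic stability, with a stated time of 10 min; a higher number here means that more of the compound is left, a lower number that less of the compound is left:

Compound 1, `CC(C)(C)OC(=O)NCCS(=O)(=O)NC(=O)c1ccc(Nc2nc(NC3(c4ccc(Cl)cc4)CC3)nc(OCC(F)(F)F)n2)cc1`: 93%
Compound 2, `CC(C)C(=O)NCCS(=O)(=O)NC(=O)c1ccc(Nc2nc(NC3(c4ccc(Cl)cc4)CC3)nc(OCC(F)(F)F)n2)cc1`: 84%
Compound 3, `CS(=O)(=O)NC(=O)c1ccc(Nc2nc(NC3(c4ccc(Cl)cc4)CC3)nc(OCC(F)(F)F)n2)cc1`: 85%

Compound 3 holds the second highest of the three numbers. Its nearest neighbour is compound 2, with a number 1 percentage points higher from compound 2 to compound 3 (within the scatter); the furthest is compound 1, with a number 8 percentage points lower from compound 1 to compound 3 (within the scatter). Neither gap is beyond the scatter, so the three measured compounds cannot be told apart on these numbers.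

Compound 4, `CC(=O)NCCS(=O)(=O)NC(=O)c1ccc(Nc2nc(NC3(c4ccc(Cl)cc4)CC3)nc(OCC(F)(F)F)n2)cc1`, differs from compound 3 in one place: acetamidomethyl in place of hydrogen on a saturated chain carbon bound to a sulfonyl sulfur.

Within the data shown here, two measured steps bear directly on this change, since both remove a substituted chain from the same saturated chain carbon bound to a sulfonyl sulfur. Going the other way, compound 1 carries ((tert-butoxycarbonyl)amino)methyl there and compound 2 carries ((isopropylcarbonyl)amino)methyl, and the steps of a number 8 percentage points lower from compound 1 to compound 3 (within the scatter) and a number 1 percentage points higher from compound 2 to compound 3 (within the scatter) were both within the scatter. The exchange between those two chains, a number 9 percentage points lower from compound 1 to compound 2 (within the scatter), was likewise within the scatter. Placing acetamidomethyl at that carbon is therefore expected to give a step of a number 2 percentage points higher from compound 3 to compound 4 (within the scatter), that is, nothing beyond the usual scatter. Compound 4 is estimated to reach 87%, within a range from 76% to 95%.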

Compound 4, percent of the compound remaining: 100%
Compound 4: middle estimate off by 13 percentage points, on the low side, and the stated range ends below it.
By their numbers in this assay, from the lowest: compounds 2, 3, 1 and 4 (each within the scatter of the next, the first and the last beyond it).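

In this assay the chain on the saturated chain carbon bound to a sulfonyl sulfur now gives a step beyond the scatter: acetamidomethyl in place of hydrogen produces a number 15 percentage points higher from compound 3 to compound 4 (beyond the scatter) and thus separates a chain-bearing compound from the hydrogen compound, which neither earlier chain had done. The end of the chain also matters here, since methyl in place of isopropyl on the carbonyl carbon gives a number 16 percentage points higher from compound 2 to compound 4 (beyond the scatter) while methyl in place of tert-butoxy on that carbon gives a number 7 percentage points higher from compound 1 to compound 4 (within the scatter) and so does not separate those two compounds, which means that compound 1 goes against any simple reading in which a smaller end group always does better. Nothing shown gives a reason for this result.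

With compound 4 at 100% the read-out has no room left above it, so a longer incubation would be needed to tell compound 4 and compound 1 apart. On these data alone, whether a free amine, a carboxylic acid or a longer chain at the same carbon would behave like the acetamidomethyl chain remains open.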